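Chain-extended acid in a fluorinated biaryl ether series

The compounds below may be only part of what the source reports. "The series", "measured", "known", "first", "only" and "open" are said of these compounds alone.

The series shares the core of compound 1, `CO[C@H]1C[C@H](Oc2cc(F)c(F)c(-c3cc(F)c(OCCCC(=O)O)c(F)c3)c2)C1`, which carries a 3-carboxypropoxy chain. In a functional assay on CHO cells for agonist activity at Free fatty acid receptor 1 (Homo sapiens), read by calcium flux (on this read-out higher numbers stand for an effect only at larger amounts of compound and lower numbers for an effect already at smaller amounts), compound 1 gives > 100000 nM, a limit of the assay and not a number. Compound 2, `CO[C@H]1C[C@H](Oc2cc(F)c(F)c(-c3cc(F)c(SCCCC(=O)O)c(F)c3)c2)C1`, has (3-carboxypropyl)sulfanyl in place of 3-carboxypropoxy on an aromatic carbon. In this assay compound 2 gives > 100000 nM, again a limit. Compound 3, `CO[C@H]1C[C@H](Oc2cc(F)c(F)c(-c3cc(F)c(OCCC(C)(C)C(=O)O)c(F)c3)c2)C1`, carries 1-carboxy-1-methylethyl in place of carboxymethyl on a saturated chain carbon, two bonds along the chain from an oxygen on an aromatic ring. In this assay compound 3 gives > 100000 nM, also a limit. The three steps among them, a step that the two limits leave unreadable from compound 1 to compound 2, a step that the two limits leave unreadable from compound 1 to compound 3 and a step that the two limits leave unreadable from compound 2 to compound 3, are unreadable because of the limit of > 100000 nM in this assay, at which 3 of the 3 values shown sit. Compound 3 thus stands at the limit alongside the other two values, none of them a number.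

Compound 4, `CO[C@H]1C[C@H](Oc2cc(F)c(F)c(-c3cc(F)c(OCCCCC(=O)O)c(F)c3)c2)C1`, differs from compound 3 by 2-carboxyethyl in place of 1-carboxy-1-methylethyl on a saturated chain carbon, two bonds along the chain from an oxygen on an aromatic ring. The measured steps bear on it only in that every chain variant so far sits at the limit; none gives a readable size or direction. Compound 4 is therefore expected to stay at the limit, with a step of a number no higher from compound 3 to compound 4 (the limit leaves the size open) expected in this assay. The expected value for compound 4 is 100000 nM, within 30000 nM to 300000 nM.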

Compound 4, half-maximal effective concentration: 68800 nM
Beside the measured number, compound 4's estimate is 1.5-fold (0.16 log units) above it, and the stated range covers the measured number.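

In this assay compound 4, with the 4-carboxybutoxy chain, is the only one of the four compounds shown that gives a number and not a limit. The 2-carboxyethyl for 1-carboxy-1-methylethyl change on the saturated chain carbon gives an at least 1.4-fold lower number from compound 3 to compound 4 (0.16 log units; that floor lies within the scatter) here, the 4-carboxybutoxy for (3-carboxypropyl)sulfanyl change on the aromatic carbon gives an at least 1.4-fold lower number from compound 2 to compound 4 (0.16 log units; that floor lies within the scatter) here, and the carboxymethyl for carboxy change on the saturated chain carbon gives an at least 1.4-fold lower number from compound 1 to compound 4 (0.16 log units; that floor lies within the scatter) here, so each step is known only as a floor. The full size of these steps cannot be read, because the other three compounds offer no number to set against compound 4: the limit of > 100000 nM in this assay, at which 3 of the 4 values shown sit.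

As far as these compounds go, whether a longer chain ending in a carboxylic acid would lower the number further in this assay stays open, as does whether a (4-carboxybutyl)sulfanyl chain would give a number at all. Also open, from the compounds shown here alone, is how an amide or a tetrazole in place of the carboxylic acid on the 4-carboxybutoxy chain would read on the shared core.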